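The compounds below may be only part of what the source reports. "The series", "measured", "known", "first", "only" and "open" are said of these compounds alone.

Compound 1 `C=CCN(C)C(=O)c1ccc(C(CC)(CC)c2ccc(OCCC(O)(CC)CC)c(C)c2)n1CC` — in a functional assay on HepG2 cells (Homo sapiens) for antiproliferative activity, read by MTT assay, with a stated time of 48 h (a higher number here means a weaker inhibitor, a lower number a stronger inhibitor), compound 1 gives > 50000 nM, which is a limit of the assay.
Compound 2 `C#CCCOC(=O)c1ccc(C(CC)(CC)c2ccc(OCCC(O)(CC)CC)c(C)c2)n1CC` — compound 2 gives > 50000 nM, again a limit.
Compound 3 `CCn1c(C(=O)Nc2cccc(C(F)(F)F)c2)ccc1C(CC)(CC)c1ccc(OCCC(O)(CC)CC)c(C)c1` — compound 3 gives > 50000 nM, also a limit.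

The three measured compounds share one core and differ only in the group attached to the carbonyl carbon. Compound 1 stands at the limit of this assay, and its standing against the other two cannot be read, because of the limit of > 50000 nM in this assay, at which 3 of the 3 values shown sit. The steps a step that the two limits leave unreadable from compound 1 to compound 2, a step that the two limits leave unreadable from compound 1 to compound 3 and a step that the two limits leave unreadable from compound 2 to compound 3 are accordingly of unknown size and direction.

Compound 4 `CCn1c(C(=O)NC(C)C(=O)O)ccc1C(CC)(CC)c1ccc(OCCC(O)(CC)CC)c(C)c1` is the next member of the series; it carries (1-carboxyethyl)amino in place of allyl(methyl)amino on a carbonyl carbon. The three measured steps all concern the same position, yet none of them offers a readable size, so no direction can be drawn from them for this change. The step that the limit leaves unreadable from compound 1 to compound 4 is therefore expected to leave compound 4 where the others sit. The estimate for compound 4 is 80000 nM, with a range from 30000 nM to 300000 nM.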

Compound 4, half-maximal inhibitory concentration: 1740 nM
The estimate for compound 4 lay 46-fold (1.66 log units) above the measured number; the measured number lies below the stated range.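

In this assay, the group on the carbonyl carbon can move the number after all, as shown by an at least 28-fold lower number from compound 1 to compound 4 (1.45 log units; beyond the scatter), an at least 28-fold lower number from compound 2 to compound 4 (1.45 log units; beyond the scatter) and an at least 28-fold lower number from compound 3 to compound 4 (1.45 log units; beyond the scatter). The step from compound 3 is the most telling, since compound 3 also has an amide-type nitrogen: that nitrogen alone does not bring the number down, and here the change is 1-carboxyethyl in place of 3-(trifluoromethyl)phenyl. The steps among compound 1, compound 2 and compound 3 still cannot be read: the limit of > 50000 nM in this assay, at which 3 of the 4 values shown sit.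

The compounds shown do not separate the part played by the carboxylic acid from that of the methyl branch of the 1-carboxyethyl group. Nor do they tell whether a methyl ester, a primary amide, an amine or a longer chain ending in a carboxylic acid would give a similar number.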